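The compounds below may be only part of what the source reports. "The series", "measured", "known", "first", "only" and "open" are said of these compounds alone.

Measured so far:
compound 1 `CN(C)CCn1cnnc1-c1cc(Oc2ccc(NC(=O)N/N=C/c3ccc(Cl)cc3)cc2F)ccn1`, 530 nM in a functional assay on HT-29 cells (Homo sapiens) for cytotoxicity, read by MTT assay, with a stated time of 72 h; a lower number here means a stronger inhibitor, a higher number a weaker inhibitor
compound 2 `CN(C)CCn1cnnc1-c1cc(Oc2ccc(NC(=O)N/N=C/c3cc(Br)c(O)c(Br)c3)cc2F)ccn1`, 2670 nM in this assay
compound 3 `CN(C)CCn1cnnc1-c1cc(Oc2ccc(NC(=O)N/N=C/c3c[nH]c4ccccc34)cc2F)ccn1`, 1300 nM in this assay

Compound 1 stands lowest of the three numbers in this assay. Compound 3 is nearest to it, with a 2.5-fold higher number from compound 1 to compound 3 (0.39 log units; beyond the scatter), and compound 2 is furthest, with a 5.0-fold higher number from compound 1 to compound 2 (0.70 log units; beyond the scatter). Between those two, a 2.1-fold lower number from compound 2 to compound 3 (0.31 log units; beyond the scatter).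

Compound 4 `COc1ccc(/C=N/NC(=O)Nc2ccc(Oc3ccnc(-c4nncn4CCN(C)C)c3)c(F)c2)cc1O` has not yet been measured. It differs from compound 1 in one place: 3-hydroxy-4-methoxyphenyl in place of 4-chlorophenyl on a carbon with a double bond to nitrogen. Both replacements of the 4-chlorophenyl measured so far raised the number, and the replacement that brought in a hydroxyl group, giving compound 2, raised it the most. The change to compound 4 also brings in a hydroxyl group on the aryl ring, so a modest rise beyond the scatter is expected in this assay, of a size between the two measured steps. The expected step is a 3.0-fold higher number from compound 1 to compound 4 (0.48 log units; beyond the scatter). For compound 4 the expected value is 1600 nM, with a range from 700 nM to 4000 nM.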

Compound 4, half-maximal inhibitory concentration: 960 nM
The estimate for compound 4 lay 1.7-fold (0.22 log units) above the measured number, and the stated range covers the measured number.
By their numbers in this assay, from the lowest: compounds 1, 4 and 3 (each within the scatter of the next, the first and the last beyond it); then compound 2.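

In this assay, 3-hydroxy-4-methoxyphenyl is the one replacement of the 4-chlorophenyl shown so far that stays within the scatter, with a 1.8-fold higher number from compound 1 to compound 4 (0.26 log units; within the scatter), and it also sits within the scatter of the 1H-indol-3-yl group, with a 1.4-fold lower number from compound 3 to compound 4 (0.13 log units; within the scatter). A hydroxyl group on the aryl ring therefore does not by itself go with the high number of the 3,5-dibromo-4-hydroxyphenyl compound, since a 2.8-fold lower number from compound 2 to compound 4 (0.44 log units; beyond the scatter), which leaves that compound alone at the top of the series. No measurement at hand bears on the reason for these differences.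

From the compounds shown here alone, it remains open whether the hydroxyl or the methoxy group sets the number for compound 4. Also open, going by these compounds, is how a phenyl ring carrying an amine or a carboxylic acid would read at this position in this assay.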